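The source may report more compounds than this note shows. Statements on the series, on what has been measured and on what is new or still open speak of the compounds shown alone.

Working notes on the series. Compound 1 `CC(C)c1ccc(-c2cc(=O)c3cc(C(=O)O)ccc3o2)cc1` gives 19% in a functional assay on the whole organism (stomach) for inhibition, with Rattus norvegicus as the target, at a dose of 80 mg/kg; a lower number here means less inhibition, a higher number more inhibition at the dose given (going by the name of the read-out). Compound 3 `CC(C)c1ccc(-c2oc3ccc(C(=O)O)cc3c(=O)c2O)cc1` gives 24%, and compound 2 `Cc1ccccc1-c1oc2ccc(C(=O)O)cc2c(=O)c1O` gives 15%; all three numbers lie within the scatter of one another, so none of them is set apart by this assay. Among the compounds with values here, the one measured step, a number 5 percentage points higher from compound 1 to compound 3 (within the scatter), concerns a different change and does not bear on the present one. Compound 4 `O=C(O)c1ccc2oc(-c3ccccc3Br)c(O)c(=O)c2c1` differs from compound 2 by bromo in place of methyl on an aromatic carbon. Within the data shown here, no measured step speaks to this change, so the expectation for compound 4 is a step of a number 2 percentage points higher from compound 2 to compound 4 (within the scatter), that is, no shift beyond the scatter. Compound 4 is therefore estimated at 17% in this assay, with a range from 5% to 30%.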

Compound 4, a percentage reported as inhibition, in the whole organism at one dose (the size of the read-out at that dose, not a potency): 22%
For compound 4 the middle estimate is 5 percentage points below the measured one; measured number inside the range.
By their numbers in this assay, from the lowest: compounds 2, 1, 4 and 3 (each within the scatter of the next).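

Bromo in place of methyl on an aromatic carbon, ortho to a large group, gives a number 7 percentage points higher from compound 2 to compound 4 (within the scatter) in this assay. At this place, the change from 2-methylphenyl to 2-bromophenyl therefore leaves the inhibition at this dose without a shift beyond the scatter. No measurement offered here accounts for this result.

From the compounds shown here alone, it remains open whether an amine, a methoxy group or a longer chain at this place would move the number beyond the scatter. Also open, going by these compounds, is whether the same holds at any other dose.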